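Pyrazolyl in place of phenyl on a biaryl sulfonamide

The source may report more compounds than this note shows. Statements on the series, on what has been measured and on what is new or still open speak of the compounds shown alone.

Measured compounds:
compound 1 `COc1ccc(NS(=O)(=O)c2ccc(-c3ccccn3)s2)cc1N1C[C@@H](C)N[C@@H](C)C1`, 15.9 nM
compound 2 `CC(C)Oc1ccc(N2C[C@@H](C)N[C@@H](C)C2)cc1NS(=O)(=O)c1ccc(-c2ccccn2)s1`, 100 nM
compound 3 `COc1ccc(N2C[C@@H](C)N[C@@H](C)C2)cc1NS(=O)(=O)c1ccc(-c2ccccc2)cc1`, 6.31 nM

In a functional assay for agonist activity at growth hormone secretagogue receptor type 1 (Homo sapiens), read by FLIPR (a lower number here means that less compound is needed, a higher number that more compound is needed for the effect), compound 3 gives the lowest of the three numbers. Compound 1 stands above it by a margin beyond the scatter, and compound 2 stands furthest off, also beyond the scatter. The unmeasured compound 4 `COc1ccc(N2C[C@@H](C)N[C@@H](C)C2)cc1NS(=O)(=O)c1ccc(-n2cccn2)cc1` differs from compound 3 in one place: 1H-pyrazol-1-yl in place of phenyl on an aromatic carbon. Among the compounds with values here, no measured pair here shows exactly this exchange, so its effect is unknown. The author expects a modest step upward in this assay, because compound 1 with 15.9 nM shows that a change at this end of the molecule can cost some potency. Compound 4 is therefore estimated at 15 nM, with a range from 5 nM to 50 nM, a step of a 2.4-fold higher number from compound 3 to compound 4 (0.38 log units; beyond the scatter).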

Compound 4, half-maximal effective concentration: 15.9 nM
Estimate against measurement, compound 4: 1.1-fold (0.03 log units) below, within the range that was stated.
By their numbers in this assay, from the lowest: compound 3; then compounds 1 and 4 (each within the scatter of the next); then compound 2.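

In this assay, 1H-pyrazol-1-yl in place of phenyl on an aromatic carbon para to a large group gives a 2.5-fold higher number from compound 3 to compound 4 (0.40 log units; beyond the scatter), a modest step. This is the first change shown at this position alone, and it shows that a five-membered aromatic ring with 2 hetero atoms keeps the number close to that of the phenyl compound, though beyond the scatter. Nothing available explains this step. The compounds shown leave open whether the ring size or the nitrogen atoms set the step, and how an amine or a carboxylic acid at this position would behave in this assay.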